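Thiourea series: aryl change on the thiourea nitrogen

The source may report more compounds than this note shows. Statements on the series, on what has been measured and on what is new or still open speak of the compounds shown alone.

Measured so far in a functional assay on HCT-116 cells (Homo sapiens) for cytotoxicity, read by MTT assay, with a stated time of 48 h; a lower number here means a stronger inhibitor, a higher number a weaker inhibitor:
compound 1 `CNC(=O)c1cc(Oc2cccc(NC(=S)Nc3ccc(Cl)cc3Cl)c2)ccn1` gives 41200 nM
compound 2 `CNC(=O)c1cc(Oc2cccc(NC(=S)Nc3ccc(F)c(F)c3)c2)ccn1` gives 30300 nM

Among the measured compounds shown here, compound 2 shows the lower of the two numbers, but the single measured step, a 1.4-fold lower number from compound 1 to compound 2 (0.13 log units; within the scatter), lies within the scatter, so compound 2 and compound 1 are not told apart by this assay.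

Compound 3 `CNC(=O)c1cc(Oc2cccc(NC(=S)Nc3cccc(C(F)(F)F)c3)c2)ccn1` is not yet measured. It differs from compound 2 only at the aryl group on the thiourea nitrogen: 3-(trifluoromethyl)phenyl in place of 3,4-difluorophenyl on an amide-type nitrogen.

For the measured compounds named here, the one step that bears on this change, the exchange of one aryl group for another at the same place, is a 1.4-fold lower number from compound 1 to compound 2 (0.13 log units; within the scatter), which did not move the number beyond the scatter. With nothing else to go on, compound 3 is expected to stay close to compound 2, with a step of about a 1.0-fold lower number from compound 2 to compound 3 (0.00 log units; within the scatter) in this assay. The estimate for compound 3 is 30000 nM, with a range from 12000 nM to 75000 nM.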

Compound 3, half-maximal inhibitory concentration: 25300 nM
For compound 3 the middle estimate is 1.2-fold (0.07 log units) above the measured one, and the stated range covers the measured number.
By their numbers in this assay, from the lowest: compounds 3, 2 and 1 (each within the scatter of the next).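

In this assay, 3-(trifluoromethyl)phenyl on the amide-type nitrogen is not told apart from 3,4-difluorophenyl (a 1.2-fold lower number from compound 2 to compound 3 (0.08 log units; within the scatter)) or from 2,4-dichlorophenyl (a 1.6-fold lower number from compound 1 to compound 3 (0.21 log units; within the scatter)). All three aryl groups at this position now lie within the scatter of one another, even with 10 heavy atoms entering in place of 8 in the step from compound 2 to compound 3. No measurement accounts for this flat result.

The aryl groups shown carry only chlorine, fluorine or trifluoromethyl, so it remains open whether an aryl ring bearing an amine or a carboxylic acid, or a longer alkyl chain on this nitrogen, would move the number beyond the scatter. As far as these compounds go, whether a change in the shared core would do so is also open.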